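This account rests on a few compounds, and the source may have more. Where it says the series, first, only, none or still open, it means among the compounds named here.

Working notes on the series.

The shared core is carried by compound 1 `O=C(Nc1ccccc1)c1c(-c2ccccc2)c(-c2ccccc2)nn1-c1ccccc1`, which in a functional assay on HEp-2 cells (Homo sapiens) for cytotoxicity, with a stated time of 24 h (on this read-out lower numbers stand for stronger inhibition and higher numbers for weaker inhibition), gives 1.5 ug/mL. Compound 2 `O=C(Nc1ccccc1)c1c(-c2ccc(Cl)cc2)c(-c2ccccc2)nn1-c1ccccc1` gives 0.74 ug/mL, and compound 3 `Cc1ccc(NC(=O)c2c(-c3ccccc3)c(-c3ccccc3)nn2-c2ccccc2)cc1` gives 1.21 ug/mL. On these three numbers compound 3 sits between compound 1 and compound 2; its gap to compound 1 is within the scatter, as is its gap to compound 2, so none of the three can be set apart from the others with confidence except through the step from compound 1 to compound 2 itself, a 2.0-fold lower number from compound 1 to compound 2 (0.31 log units; beyond the scatter).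

Compound 4 `Cc1ccc(NC(=O)c2c(-c3ccccc3)c(-c3ccc(Cl)cc3)nn2-c2ccccc2)cc1` is not yet measured. It differs from compound 3 by chloro in place of hydrogen on an aromatic carbon. The closest measured guide is the step from compound 1 to compound 2, a 2.0-fold lower number from compound 1 to compound 2 (0.31 log units; beyond the scatter), although in compound 2 the chloro sits on another of the phenyl groups of the core, so the match is not exact. The step from compound 1 to compound 3, a 1.2-fold lower number from compound 1 to compound 3 (0.09 log units; within the scatter), shows that the methyl on the anilide contributes little, so the chloro is expected to be the deciding change here too.

For compound 4 a step of about a 2.0-fold lower number from compound 3 to compound 4 (0.30 log units; within the scatter) is therefore expected. Compound 4 is estimated at 0.6 ug/mL, with a range from 0.3 ug/mL to 1.3 ug/mL.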

Compound 4, half-maximal inhibitory concentration: 1.21 ug/mL
For compound 4 the middle estimate is 2.0-fold (0.30 log units) below the measured one, and the stated range covers the measured number.
By their numbers in this assay, from the lowest: compounds 2, 3, 4 and 1 (each within the scatter of the next, the first and the last beyond it).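

In this assay, the change from phenyl to 4-chlorophenyl on the core of compound 3 gives no change at the digits printed from compound 3 to compound 4 (within the scatter), so chloro in place of hydrogen at this place, para to a large group, has no readable effect on this core. Going by these compounds alone, the earlier chloro step therefore cannot be taken as a dependable gain across the series, since it was the only chloro step available until now and it lay just beyond the scatter. Even so, the two steps cannot be told apart, and a real difference between them is not established, with the chloro of compound 2 on another phenyl group of the core and without the methyl on the anilide: the same change on two cores in this assay, a 2.0-fold lower number (0.31 log units; beyond the scatter) from compound 1 to compound 2 and no change at the digits printed (within the scatter) from compound 3 to compound 4, 2.0-fold (0.31 log units) apart, within the scatter of two such steps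

The compounds shown leave open whether chloro behaves differently at the two phenyl groups or whether the methyl on the anilide alters its effect, as these two differences are not separated here. From the compounds shown here alone, it also remains open how an amine, a carboxylic acid or a methoxy group at this same place would compare with chloro and with hydrogen in this assay.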